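The source may report more compounds than this note shows. Statements on the series, on what has been measured and on what is new or still open speak of the compounds shown alone.

Measured compounds:
compound 1 `Cc1ccc2oc(-c3ccc(NC(=O)CN4CCN(CCCN(C)C)CC4)cc3)nc2c1` gives 26400 nM
compound 2 `Cc1cc(-c2nc3cc(Cl)ccc3o2)ccc1NC(=O)CCl` gives 8640 nM
compound 3 `CN(C)CCCN1CCN(CC(=O)Nc2ccc(-c3nc4cc(Cl)ccc4o3)cc2)CC1` gives 25800 nM

These three compounds were tested in an ADME assay on NIH3T3 cells (Mus musculus) for cytotoxicity, read by MTT assay, with a stated time of 24 h; a lower number here means a stronger inhibitor, a higher number a weaker inhibitor. Compound 2 has the lowest number of the three, beyond the scatter from both others, so it is the strongest inhibitor here. Compound 2 and compound 3 differ in more than one place, and the difference between their two cores is not broken down here.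

Compound 1 and compound 3 differ by a single change, (methyl in place of chloro on an aromatic carbon). This produced a 1.0-fold higher number from compound 3 to compound 1 (0.01 log units; within the scatter), a step that lies within the scatter.

Compound 4 `Cc1ccc2oc(-c3ccc(NC(=O)CCl)c(C)c3)nc2c1` has not yet been measured. It comes from compound 2 by methyl in place of chloro on an aromatic carbon, the same change that led from compound 3 to compound 1, at the same place on the same kind of ring. Since that earlier step was within the scatter, the step from compound 2 to compound 4 is expected to be small too, about a 1.0-fold higher number from compound 2 to compound 4 (0.00 log units; within the scatter). Compound 4 is therefore estimated to give about 8700 nM, most likely between 4000 nM and 19000 nM.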

Compound 4, half-maximal inhibitory concentration: 6790 nM
Estimate against measurement, compound 4: 1.3-fold (0.11 log units) above; the range from low to high includes it.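

In this assay, methyl in place of chloro on an aromatic carbon gives a 1.3-fold lower number from compound 2 to compound 4 (0.10 log units; within the scatter), so on this core, too, the swap leaves no reading beyond the scatter. Set beside the earlier step, the change looks the same on both cores: the same change on two cores in this assay, a 1.0-fold higher number (0.01 log units; within the scatter) from compound 3 to compound 1 and a 1.3-fold lower number (0.10 log units; within the scatter) from compound 2 to compound 4, 1.3-fold (0.11 log units) apart, within the scatter of two such steps

Among the compounds shown here, this shows that, for these two pairs, the swap carried over from one core to the other with no step beyond the scatter, but it does not show that methyl and chloro can be exchanged freely across the series or in any other test, as only two pairs in a single assay are available.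

Left open is whether other groups at this place, such as fluoro, methoxy or an amine, would give a step beyond the scatter and whether such a step would also carry across both cores. Also open is whether the swap would stay this small on a core bearing a carboxylic acid or a longer chain instead of the side chains shown.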